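A Ring Swap in the Thiophene Series

The compounds below may be only part of what the source reports. "The series", "measured", "known", "first", "only" and "open" are said of these compounds alone.

- compound 1 `NC1CCC(Nc2nc(NCc3ccc(-c4ccsc4)cc3)c3ncn(C4CCCC4)c3n2)CC1`: 120 nM
- compound 2 `CC(C)(O)CNc1nc(NCc2ccc(-c3ccco3)cc2)c2ncn(C3CCCC3)c2n1`: 21400 nM
- compound 3 `NC1CCC(Nc2nc(NCc3ccc(-c4ccco4)nc3)c3ncn(C4CCCC4)c3n2)CC1`: 44 nM

All three values were measured in a functional assay on HOS cells (Homo sapiens) for inhibition, with a stated time of 72 h; a lower number here means a stronger inhibitor, a higher number a weaker inhibitor. Compound 1 stands in the middle of the three, with compound 3 lower and compound 2 far higher. Compound 4 `NC1CCC(Nc2nc(NCc3ccc(-c4ccsc4)nc3)c3ncn(C4CCCC4)c3n2)CC1` has not been measured. It differs from compound 1 in one place, on a saturated chain carbon bound to a nitrogen on an aromatic ring: 6-(thiophen-3-yl)pyridin-3-yl in place of 4-(thiophen-3-yl)phenyl on a saturated chain carbon bound to a nitrogen on an aromatic ring. The thiophen-3-yl stays, while the six-membered aromatic ring of carbon only becomes one with 1 hetero atom.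

Within the data shown here, one measured step bears on this change: a 2.7-fold lower number from compound 1 to compound 3 (0.44 log units; beyond the scatter). That modest step makes the same ring change but also replaces thiophen-3-yl with furan-2-yl, so the data cannot show how much belongs to each change. Compound 2 differs from compound 1 in more than one place and offers no direct guide. A smaller step in the same direction therefore seems likely. The expected change is a 1.8-fold lower number from compound 1 to compound 4 (0.27 log units; within the scatter). Compound 4 is estimated at 65 nM, with an expected range of 25 nM to 170 nM.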

Compound 4, half-maximal inhibitory concentration: 89 nM
The estimate for compound 4 lay 1.4-fold (0.14 log units) below the measured number, within the range that was stated.
By their numbers in this assay, from the lowest: compound 3; then compounds 4 and 1 (each within the scatter of the next); then compound 2.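

Placing 6-(thiophen-3-yl)pyridin-3-yl in place of 4-(thiophen-3-yl)phenyl gives a 1.3-fold lower number from compound 1 to compound 4 (0.13 log units; within the scatter) in this assay and so, taken alone, this ring change cannot be told apart from no change at all. The other new step, a 2.0-fold higher number from compound 3 to compound 4 (0.31 log units; beyond the scatter), separates out the five-membered ring, since thiophen-3-yl in place of furan-2-yl on an aromatic carbon is the only difference, and this modest step lies beyond the scatter. No outside measurement is available to explain the size of either step.

The compounds shown leave open how a quite different group on that aromatic carbon, such as an amine or a carboxylic acid, would compare with thiophen-3-yl and furan-2-yl. They also leave open whether these two steps would keep their size with a longer chain in place of the saturated chain carbon that carries this ring system.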